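Carboxy in Place of Dimethylamino, Tried a Second Time

A few compounds are considered here, and "the series" means these few. Any claim that something is new, unique, unknown or untested is made for them only; others in the source may bear on it.

Compound 1, `CN(C)c1ccc(-c2cc(C(=O)c3ccccc3)c(N)s2)cc1`, gives 50% in an assay on CHO cells for positive allosteric modulation of adenosine receptor A1 (Homo sapiens), read by ERK phosphorylation, tested at 3 uM; on this read-out higher numbers stand for a weaker effect at the one concentration tested and lower numbers for a stronger effect.
Compound 2, `Nc1sc(-c2ccc(C(=O)O)cc2)cc1C(=O)c1ccccc1`, gives 51%.
Compound 3, `CN(C)c1ccc(-c2cc(C(=O)c3ccc(Cl)cc3)c(N)s2)cc1`, gives 56%.

Of the compounds shown here, three have been measured, and a fourth, compound 4 with the structure `Nc1sc(-c2ccc(C(=O)O)cc2)cc1C(=O)c1ccc(Cl)cc1`, awaits its turn in this assay. The three measured values lie within the usual scatter of one another, so none of them can be called stronger or weaker than the rest.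

The change from compound 1 to compound 2 is carboxy in place of dimethylamino on an aromatic carbon. It produced a step of a number 1 percentage points higher from compound 1 to compound 2 (within the scatter), which is within the scatter. Compound 4 carries the same change relative to compound 3, namely (carboxy in place of dimethylamino on an aromatic carbon), and the surroundings of the place are the same in both pairs.

The two parent compounds differ in their cores by chloro in place of hydrogen on an aromatic carbon. That difference gave a step of a number 6 percentage points higher from compound 1 to compound 3 (within the scatter), again within the scatter.

For the measured compounds named here, with only one earlier instance of the change to go by, the expectation is that the step from compound 3 to compound 4 will be a number 1 percentage points higher from compound 3 to compound 4 (within the scatter), about the size of the earlier one, because the step of a number 1 percentage points higher from compound 1 to compound 2 (within the scatter) was within the scatter. Compound 4 is therefore estimated at 57%, with a likely range from 45% to 70%.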

Compound 4, a percentage reported as activity, at one concentration (the size of the read-out at that concentration, not a potency): 27%
Compound 4: the middle estimate sits 30 percentage points above what was measured; the measured number lies below the stated range.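

In this assay, carboxy in place of dimethylamino on an aromatic carbon gave a number 29 percentage points lower from compound 3 to compound 4 (beyond the scatter) on the core that carries chloro, and this step did not repeat the one seen on the core without chloro: the same change on two cores in this assay, a number 1 percentage points higher (within the scatter) from compound 1 to compound 2 and a number 29 percentage points lower (beyond the scatter) from compound 3 to compound 4, 30 percentage points apart, beyond the scatter of two such steps. Read the other way, chloro in place of hydrogen on an aromatic carbon gave a number 24 percentage points lower from compound 2 to compound 4 (beyond the scatter) with carboxy present, and this too differed from the step seen with dimethylamino present: the same change on two cores in this assay, a number 6 percentage points higher (within the scatter) from compound 1 to compound 3 and a number 24 percentage points lower (beyond the scatter) from compound 2 to compound 4, 30 percentage points apart, beyond the scatter of two such steps. The size of neither change therefore carries over from one core to the other in these four compounds, and the lower number, which stands for a stronger effect, appears only in compound 4, where carboxy and chloro occur together, but a single set of four compounds does not show why this happens or whether it holds elsewhere in the series.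

Going by these compounds, it remains open whether a fluoro or bromo group in place of the chloro, or a methyl ester or primary amide in place of the carboxy, would keep the lower number of compound 4. On these data alone, it also remains open whether the same interplay would appear with either group placed elsewhere on its ring.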